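The source may report more compounds than this note shows. Statements on the series, on what has been measured and on what is new or still open speak of the compounds shown alone.

Compound 2, with the structure `C/C(=C\C(=O)Nc1ccccc1OCCCC(=O)O)c1ccc2c(ccn2C(C(C)C)C(C)C)c1`, gives 14 nM in an assay on Prostate gland for inhibition of steroid 5-alpha-reductase (Rattus norvegicus); on this read-out higher numbers stand for weaker inhibition and lower numbers for stronger inhibition. Going by the values given here, of the two numbers measured so far it stands highest, but its only neighbour, compound 1 with the structure `CCCCC(CC)n1ccc2cc(/C(C)=C/C(=O)Nc3ccccc3OCCCC(=O)O)ccc21`, gives 7.1 nM in this assay, and the step of a 2.0-fold higher number from compound 1 to compound 2 (0.29 log units; within the scatter) lies within the usual scatter of this kind of measurement, so the two compounds cannot be told apart on inhibition.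

Compound 3, with the structure `CCC(c1ccccc1)n1ccc2cc(/C(C)=C/C(=O)Nc3ccccc3OCCCC(=O)O)ccc21`, is the next compound to be measured. It differs from compound 2 in one place: 1-phenylpropyl in place of 1-isopropyl-2-methylpropyl on an aromatic nitrogen. Among the compounds with values here, the only measured step that bears on this position is the one from compound 1 to compound 2, where one branched chain on the aromatic nitrogen was exchanged for another and the number moved by a 2.0-fold higher number from compound 1 to compound 2 (0.29 log units; within the scatter), within the scatter. Within the data shown here, the new group brings a six-membered aromatic ring, which neither measured compound carries, so that part of the change has no precedent here.

With nothing beyond the scatter seen at this position, compound 3 is expected to give about 10 nM in this assay, between 3 nM and 35 nM, meaning an estimated step of a 1.4-fold lower number from compound 2 to compound 3 (0.15 log units; within the scatter).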

Compound 3, half-maximal inhibitory concentration: 19 nM
Beside the measured number, compound 3's estimate is 1.9-fold (0.28 log units) below it; the range from low to high includes it.
By their numbers in this assay, from the lowest: compounds 1, 2 and 3 (each within the scatter of the next, the first and the last beyond it).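

The aromatic nitrogen can carry a group with a six-membered aromatic ring without a clear loss of inhibition: in this assay, 1-phenylpropyl in place of 1-isopropyl-2-methylpropyl gives a 1.4-fold higher number from compound 2 to compound 3 (0.13 log units; within the scatter) and so leaves the two compounds indistinguishable, even though the entering group has 9 heavy atoms and the leaving group 7. Going by these compounds alone, the same ring does separate two compounds when it is read against a straight chain: phenyl in place of butyl on a saturated chain carbon bound to an aromatic nitrogen and a saturated chain carbon gives a 2.7-fold higher number from compound 1 to compound 3 (0.43 log units; beyond the scatter) and is the first step at this position to pass the scatter, though only modestly. No measurement at hand accounts for either step.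

The compounds shown leave open whether the modest rise depends on the phenyl ring itself or would also appear with a cyclohexyl ring in its place. They also leave open how a phenyl ring carrying a fluorine atom or a methoxy group, or a pyridine ring in place of the phenyl, would read in this assay.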